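Swapping an acid-bearing ring for a small heteroaromatic ring

This account rests on a few compounds, and the source may have more. Where it says the series, first, only, none or still open, it means among the compounds named here.

Compound 1 `CCC(C)(C)Cc1c[nH]c(CCc2ccc(-n3ncnn3)cc2)n1`: 205 nM
Compound 2 `CCC(C)(C)Cc1c[nH]c(CCc2ccc(-n3ccnn3)cc2)n1`: 390 nM
Compound 3 `CCC(C)(C)Cc1c[nH]c(CCc2ccc(-c3ccccc3C(=O)O)cc2)n1`: 11 nM

Three compounds share one core and differ only in the group attached at the far end. In an in vitro assay on CHO cells for displacement of a labelled ligand from Bombesin receptor subtype-3 (Homo sapiens), read by scintillation counting, with a stated time of 2 h (a lower number here means a stronger inhibitor, a higher number a weaker inhibitor), compound 3 gives the lowest number of the three; its nearest neighbour is compound 1, and the gap is a 19-fold lower number from compound 1 to compound 3 (1.27 log units; beyond the scatter) read the other way, while against compound 2 the gap is a 35-fold lower number from compound 2 to compound 3 (1.55 log units; beyond the scatter). Between compound 1 and compound 2 the step is a 1.9-fold higher number from compound 1 to compound 2 (0.28 log units; within the scatter).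

Compound 4 `CCC(C)(C)Cc1c[nH]c(CCc2ccc(-c3cnsc3)cc2)n1` is not yet measured. It differs from compound 3 in one place: 1,2-thiazol-4-yl in place of 2-carboxyphenyl on an aromatic carbon. The two measured steps that bear on this are the ones that took compound 1 and compound 2, each carrying a five-membered heteroaromatic ring, to compound 3 with its 2-carboxyphenyl group; both were large drops in number. Compound 4 returns to a five-membered heteroaromatic ring, so a large rise in number is expected in this assay, roughly back toward where compound 1 and compound 2 sit, giving a 23-fold higher number from compound 3 to compound 4 (1.36 log units; beyond the scatter). Compound 4 is therefore estimated at 250 nM, with a range from 60 nM to 1000 nM.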

Compound 4, half-maximal inhibitory concentration: 10 nM
Compound 4: middle estimate off by 25-fold (1.40 log units), on the high side, outside the stated range (below it).
By their numbers in this assay, from the lowest: compounds 4 and 3 (each within the scatter of the next); then compounds 1 and 2 (each within the scatter of the next).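

Replacing 2-carboxyphenyl with 1,2-thiazol-4-yl gives a 1.1-fold lower number from compound 3 to compound 4 (0.04 log units; within the scatter) in this assay, so a carboxylic acid on the ring at this position is not needed for a low number. A five-membered aromatic ring does not bring a high number on its own either: the steps are a 39-fold lower number from compound 2 to compound 4 (1.59 log units; beyond the scatter) and a 21-fold lower number from compound 1 to compound 4 (1.31 log units; beyond the scatter), both large. Among these four compounds, then, the identity of the ring matters more than its size or whether it carries an acid.

A plain phenyl ring would show what the carboxylic acid of compound 3 adds, if anything, and a thiophene ring would show whether the nitrogen of the 1,2-thiazol-4-yl group matters. Nothing measured here explains why these rings differ.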